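Pyrazole in Place of Phenyl on the Amide

The compounds below may be only part of what the source reports. "The series", "measured", "known", "first", "only" and "open" are said of these compounds alone.

Measured compounds:
compound 1 `CNC(=O)N1CCCc2ccc(NC(=O)c3cccc(-c4ccccc4)c3)cc21`: 2.83%
compound 2 `CNC(=O)N1CCCc2ccc(NC(=O)c3ccc(-c4ccn(C)n4)cc3)cc21`: 72.2%

In a functional assay on MV4-11 cells (Homo sapiens) for antiproliferative activity, with a stated time of 6 days, tested at 1.56 uM (on this read-out higher numbers stand for a stronger effect at the one concentration tested and lower numbers for a weaker effect), compound 1 gives 2.83%, the lowest of the two numbers. The nearest number is that of compound 2, which gives 72.2%, a gap beyond the usual scatter. Compound 3 `CNC(=O)N1CCCc2ccc(NC(=O)c3cccc(-c4cnn(S(C)(=O)=O)c4)c3)cc21` has not yet been measured; it differs from compound 1 in one place: 1-(methylsulfonyl)-1H-pyrazol-4-yl in place of phenyl on an aromatic carbon.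

For the measured compounds named here, no step between measured compounds that differ in only one place is available, so the expected size of this change rests on the two values alone, in which compound 2 stands far above compound 1. The step of a number 32.2 percentage points higher from compound 1 to compound 3 (beyond the scatter) is expected to be upward and beyond the scatter, but with wide uncertainty, since no directly comparable change has been measured. Compound 3 is therefore estimated to give 35%, with a range from 5% to 75%.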

Compound 3, a percentage reported as inhibition, at one concentration (the size of the read-out at that concentration, not a potency): 1.6%
The estimate for compound 3 lay 33.4 percentage points above the measured number; the measured number lies below the stated range.
By their numbers in this assay, from the lowest: compounds 3 and 1 (each within the scatter of the next); then compound 2.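

In this assay, putting 1-(methylsulfonyl)-1H-pyrazol-4-yl in place of phenyl on this aromatic carbon, meta to a large group, gives a number 1.2 percentage points lower from compound 1 to compound 3 (within the scatter). This is the first single-place change shown at this position, and it indicates that exchanging phenyl for this five-membered aromatic ring with 2 hetero atoms, which brings 4 hydrogen-bond acceptors, is not enough on its own to produce a change in the read-out beyond the scatter. No measurement bears on why the number stays where it is.

Compound 2 differs from compound 1 in more than one place, so what separates its value from theirs remains unresolved. Going by these compounds, it is also open whether a pyridine, an amine or a carboxylic acid on this aromatic carbon would give a different number.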